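An Ethyl for a Methyl at the Solubility Limit

The source may hold more compounds than are shown below. What is called first, only, known or untested is meant among the compounds shown, and "the series" means these compounds.

In a physicochemical assay for solubility, read by HPLC, in phosphate buffer, measured as kinetic solubility, with a stated time of 1 h, at pH 7.4, tested at 250 uM (on this read-out lower numbers stand for lower solubility and higher numbers for higher solubility), compound 1 (`CC(=O)N1CCC(c2ccc3c(c2)oc(=O)n3C(=O)NCCCCc2ccccc2)CC1`) gives < 1000 nM as its reading, which is a limit of the assay and not a number. Compound 2 (`CN1CCN(c2ccc3c(c2)oc(=O)n3C(=O)NCCCCc2ccccc2)CC1`) gives < 1000 nM as its reading, again a limit and not a number, so it has no exact place on the scale. The evidence amounts to the limit of < 1000 nM in this assay, at which 2 of the 2 values shown sit, and nothing finer. Among the measured compounds shown here, the one measured change is a step that the two limits leave unreadable from compound 1 to compound 2 and offers no size to carry forward. Compound 3 (`CCN1CCN(c2ccc3c(c2)oc(=O)n3C(=O)NCCCCc2ccccc2)CC1`) carries 4-ethylpiperazin-1-yl where compound 2 carries 4-methylpiperazin-1-yl, with methyl in place of hydrogen on a saturated chain carbon bound to an amine nitrogen in a ring as the whole difference. With no readable step behind it, a step that the limit leaves unreadable from compound 2 to compound 3 is expected to stay within the usual scatter, in no particular direction. Compound 3 is expected at 700 nM within a range of 300 nM to 1600 nM and may well return only a limit again.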

Compound 3, solubility: < 1000 nM
Compound 3: a limit, no number (the forecaster's own chance of this, stated with the estimate: 85%); the middle value is on the limit's open side.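

Compound 3 also returns a limit and not a number, so no step among compound 1, compound 2 and compound 3 can be read, and the evidence stays at this: the limit of < 1000 nM in this assay, at which 3 of the 3 values shown sit.

On these data alone, the true solubility of all three compounds, and whether their differing groups change it, stays open.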